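This account rests on a few compounds, and the source may have more. Where it says the series, first, only, none or still open, it means among the compounds named here.

Among the measured compounds shown here, in an ADME assay on MT4 cells (Homo sapiens) for cytotoxicity, read by MTT assay (a higher number here means that more compound is tolerated, a lower number that less compound is tolerated), three compounds sharing one core have numbers so far: compound 1 `O=C1c2ccccc2C(=O)N1CCOC(=S)N(C(=O)c1cc(F)ccc1F)c1ccc(Cl)cc1` gives 54000 nM, compound 2 `O=C1c2ccccc2C(=O)N1CCOC(=S)N(C(=O)c1ccc(Cl)c(Cl)c1)c1ccc(Cl)cc1` gives 35000 nM, and compound 3 `O=C1c2ccccc2C(=O)N1CCOC(=S)N(C(=O)c1ccc([N+](=O)[O-])cc1Cl)c1ccc(Cl)cc1` gives 19000 nM. Two steps show where compound 3 stands: a 2.8-fold lower number from compound 1 to compound 3 (0.45 log units; beyond the scatter), and a 1.8-fold lower number from compound 2 to compound 3 (0.27 log units; within the scatter).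

Compound 4 `O=C1c2ccccc2C(=O)N1CCOC(=S)N(C(=O)c1cc([N+](=O)[O-])ccc1Cl)c1ccc(Cl)cc1` has not yet been measured. It has the same atoms as compound 3, joined differently: 2-chloro-5-nitrophenyl in place of 2-chloro-4-nitrophenyl on a carbonyl carbon. In words, this is 2-chloro-5-nitrophenyl in place of 2-chloro-4-nitrophenyl on a carbonyl carbon.

For the measured compounds named here, no measured step makes this exact exchange. The nearest evidence comes from the steps that replace the group on that same carbonyl carbon: the two above and a 1.5-fold lower number from compound 1 to compound 2 (0.19 log units; within the scatter). All of them are small, and only one goes beyond the scatter. A similarly small change is therefore expected here, with no firm direction. The expected step, a 1.3-fold higher number from compound 3 to compound 4 (0.10 log units; within the scatter), stays within the scatter. Compound 4 is estimated at 24000 nM, with an expected range from 11000 nM to 55000 nM.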

Compound 4, half-maximal cytotoxic concentration: 45000 nM
Compound 4: the middle estimate sits 1.9-fold (0.27 log units) below what was measured; the measured number falls inside the stated range.
By their numbers in this assay, from the lowest: compounds 3, 2, 4 and 1 (each within the scatter of the next, the first and the last beyond it).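

In this assay, exchanging 2-chloro-4-nitrophenyl for 2-chloro-5-nitrophenyl on the carbonyl carbon gives a step beyond the scatter (a 2.4-fold higher number from compound 3 to compound 4 (0.37 log units; beyond the scatter)), so at this position the way the same atoms are joined matters, and not only which atoms are present. Compound 4 also lies within the scatter of the two halogen-only compounds (a 1.3-fold higher number from compound 2 to compound 4 (0.11 log units; within the scatter); a 1.2-fold lower number from compound 1 to compound 4 (0.08 log units; within the scatter)), which shows that carrying a nitro group on this phenyl does not in itself bring the number down to that of compound 3. Nothing available here accounts for the difference between the two arrangements.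

From the compounds shown here alone, whether an amino group or a carboxylic acid in place of the nitro group would give a number nearer compound 3 or compound 4 remains open. So does the outcome with a cyclohexyl group on the carbonyl carbon in place of a phenyl.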